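The source may hold more compounds than are shown below. What is called first, only, known or untested is meant among the compounds shown, and "the series" means these compounds.

Measured so far in an ADME assay on microsomes from liver (Homo sapiens) for metabolic stability, read by LC-MS, using NADPH, tested at 3 uM; on this read-out lower numbers stand for a shorter-lived compound and higher numbers for a longer-lived compound:
- compound 1 `Cc1ccc2c(C(c3cccs3)C(C#N)C#N)c(-c3ccccc3)[nH]c2c1`: 0.52 h
- compound 2 `Cc1ccc2c(C(C(=O)C(F)(F)F)c3ccccc3)c(-c3ccccc3)[nH]c2c1`: 4.45 h
- compound 3 `Cc1ccc2c(C(CC(F)(F)F)c3ccccc3)c(-c3ccccc3)[nH]c2c1`: 1.45 h

Compound 3 holds the middle place, with compound 1 below it and compound 2 above it, both beyond the scatter. Compound 4 `Cc1ccc2c(C(CC(F)(F)F)c3cccs3)c(-c3ccccc3)[nH]c2c1` is compound 3 with one change: thiophen-2-yl in place of phenyl on a saturated chain carbon bound to an aromatic carbon and a saturated chain carbon. For the measured compounds named here, the only measured step, a 3.1-fold lower number from compound 2 to compound 3 (0.49 log units; beyond the scatter), lies at a different group, so it shows only how far one change can move these numbers. Going by the values given here, no measured pair isolates thiophen-2-yl against phenyl. Compound 1 carries thiophen-2-yl and gives 0.52 h, but it also differs from compound 3 in another group, so it is weak evidence for direction. A modest fall in this assay, no larger than the measured step, is expected. The expected change is a 1.5-fold lower number from compound 3 to compound 4 (0.16 log units; within the scatter). The estimate for compound 4 is 1 h, with an expected range from 0.5 h to 1.9 h.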

Compound 4, half-life: 1.8 h
Compound 4: the middle estimate sits 1.8-fold (0.26 log units) below what was measured; the range from low to high includes it.
By their numbers in this assay, from the lowest: compound 1; then compounds 3 and 4 (each within the scatter of the next); then compound 2.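

In this assay, thiophen-2-yl in place of phenyl on this saturated chain carbon gives a 1.2-fold higher number from compound 3 to compound 4 (0.09 log units; within the scatter), so the two rings are not told apart here. With thiophen-2-yl held fixed, 2,2,2-trifluoroethyl in place of dicyanomethyl gives a 3.5-fold higher number from compound 1 to compound 4 (0.54 log units; beyond the scatter), which places the low number of compound 1 with its dicyanomethyl group and not with its ring. Nothing available explains either step.

Open, on these data alone, is whether the ring swap reads the same with the (trifluoromethyl)carbonyl group of compound 2. Also open, as far as these compounds go, is how a pyridine ring or a cyclohexyl group would read at this carbon.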